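The source may report more compounds than this note shows. Statements on the series, on what has been measured and on what is new or still open speak of the compounds shown alone.

Three close relatives share one core, and differ only in the aryl group attached to the ring with two nitrogens. Compound 1 `COc1ccc(-c2nc(SCC(=O)c3sc(-c4ccc(Cl)cc4)nc3C)[nH]c(=O)c2C#N)cc1` gives 46.3% in a functional assay on U-87MG ATCC cells for antiproliferative activity against U-87 MG (Homo sapiens), read by MTT assay, with a stated time of 48 h, tested at 50 uM; on this read-out higher numbers stand for a weaker effect at the one concentration tested and lower numbers for a stronger effect. Compound 2 `COc1ccc(-c2nc(SCC(=O)c3sc(-c4ccc(Cl)cc4)nc3C)[nH]c(=O)c2C#N)cc1OC` gives 59.8%, and compound 3 `Cc1nc(-c2ccc(Cl)cc2)sc1C(=O)CSc1nc(-c2ccc(Cl)cc2)c(C#N)c(=O)[nH]1` gives 60%. Compound 3 thus holds the highest of the three numbers, though its value and that of compound 2 lie within the scatter of each other, while compound 1 sits clearly lower, as the step of a number 13.7 percentage points higher from compound 1 to compound 3 (beyond the scatter) shows.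

Compound 4 `COc1cccc(-c2nc(SCC(=O)c3sc(-c4ccc(Cl)cc4)nc3C)[nH]c(=O)c2C#N)c1` has not yet been measured. It differs from compound 3 in one place: 3-methoxyphenyl in place of 4-chlorophenyl on an aromatic carbon. Among the measured compounds shown here, two measured steps bear on this. The step of a number 13.7 percentage points higher from compound 1 to compound 3 (beyond the scatter) shows that replacing a methoxy by chloro raised the number modestly, and the step of a number 0.2 percentage points higher from compound 2 to compound 3 (within the scatter) shows that exchanging 3,4-dimethoxyphenyl for 4-chlorophenyl changed nothing beyond the scatter. Going back from chloro to a methoxy, now placed as 3-methoxyphenyl, is therefore expected to lower the number somewhat, by about a number 8 percentage points lower from compound 3 to compound 4 (within the scatter). Compound 4 is accordingly estimated at 52%, within a range from 38% to 66%.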

Compound 4, a percentage reported as activity, at one concentration (the size of the read-out at that concentration, not a potency): 47.6%
Compound 4: the middle estimate sits 4.4 percentage points above what was measured; measured number inside the range.
By their numbers in this assay, from the lowest: compounds 1 and 4 (each within the scatter of the next); then compounds 2 and 3 (each within the scatter of the next).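

The placement of a single methoxy on this aryl group makes no difference that can be read here: a number 1.3 percentage points higher from compound 1 to compound 4 (within the scatter), so 3-methoxyphenyl and 4-methoxyphenyl cannot be told apart in this assay. Both 4-chlorophenyl and 3,4-dimethoxyphenyl differ from 3-methoxyphenyl by more than the scatter, with a number 12.4 percentage points lower from compound 3 to compound 4 (beyond the scatter) and a number 12.2 percentage points lower from compound 2 to compound 4 (beyond the scatter), and these lower numbers stand for a stronger effect at the one concentration tested. Nothing available explains why these groups differ.

Going by these compounds, it remains open what a plain phenyl, or a phenyl carrying an amine or a carboxylic acid, would give at this position, and whether 3-chlorophenyl would match 4-chlorophenyl. A read-out at one concentration shows only a stronger or weaker effect at that concentration.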